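The source may hold more compounds than are shown below. What is called first, only, known or untested is meant among the compounds shown, and "the series" means these compounds.

Measured so far:
Compound 1 `C=CC[C@H]1C[C@]2([C@@H](C)Cc3cc(C)c(OC)cc3F)OCOC2=CC1=O` — in a functional assay on M14 cells (Homo sapiens) for antiproliferative activity, with a stated time of 72 h (on this read-out lower numbers stand for stronger inhibition and higher numbers for weaker inhibition), compound 1 gives 230 nM.
Compound 2 `C=CC[C@H]1C[C@]2([C@@H](C)Cc3cc(C#N)c(OC)cc3F)OCOC2=CC1=O` — in this assay compound 2 gives 37 nM.

Going by the values given here, compound 2 holds the lower of the two numbers; the only measured step, a 6.2-fold lower number from compound 1 to compound 2 (0.79 log units; beyond the scatter), separates it from compound 1. Compound 3 `C=CC[C@H]1C[C@]2([C@@H](C)Cc3cc(N)c(OC)cc3F)OCOC2=CC1=O` differs from compound 2 by amino in place of cyano on an aromatic carbon. That single measured step bears on this change only indirectly: it shows that the group on this aromatic carbon moves the number in this assay beyond the scatter, but neither group already tried is an amino group, so the direction of the new step is not settled by it. With no closer comparison, amino is taken as an intermediate case between the two groups seen, and a moderate rise back toward compound 1 is expected: a 2.7-fold higher number from compound 2 to compound 3 (0.43 log units; beyond the scatter). For compound 3 the estimate in this assay is 100 nM, with a range of 30 nM to 350 nM.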

Compound 3, half-maximal inhibitory concentration: 29 nM
Beside the measured number, compound 3's estimate is 3.4-fold (0.54 log units) above it; the whole stated range lies above it.
By their numbers in this assay, from the lowest: compounds 3 and 2 (each within the scatter of the next); then compound 1.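

In this assay, the change from cyano to amino on this aromatic carbon, ortho to a methoxy group, gives a 1.3-fold lower number from compound 2 to compound 3 (0.11 log units; within the scatter), so the hydrogen-bond donor that amino brings and cyano lacks does not separate the two here. Set against methyl, amino gives a 7.9-fold lower number from compound 1 to compound 3 (0.90 log units; beyond the scatter), which, alongside a 6.2-fold lower number from compound 1 to compound 2 (0.79 log units; beyond the scatter), shows that two quite different groups each stand apart from methyl at this position, so the earlier step was not particular to cyano. No measured evidence is at hand on what lies behind this.

Still open, on these data alone, is whether a substituted nitrogen group, such as an acetamide or a dimethylamino group, holds the number at this level, and whether a hydroxyl group or a chlorine atom does too. The compounds shown also leave open whether the same holds when the neighbouring methoxy group is replaced by an ethoxy group or a hydroxyl group.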